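Hydroxy Added to Compound 2: What Binding to Expect

This account rests on a few compounds, and the source may have more. Where it says the series, first, only, none or still open, it means among the compounds named here.

Measured so far:
Compound 1, `CN1CCCN(CCn2ccc3ccc(C(F)(F)F)cc32)CC1`: 89%
Compound 2, `CC(C)c1ccc2ccn(CCN3CCCN(C)CC3)c2c1`: 72%

Both compounds were tested in an assay on HEK293 cells for binding affinity to 5-hydroxytryptamine receptor 7 (Homo sapiens), read by radioligand binding, tested at 1 uM; a higher number here means more inhibition at the concentration tested (going by the name of the read-out), a lower number less inhibition. In this assay compound 1 gives 89%, and compound 2 gives 72%. Among the compounds with values here, compound 2 thus stands lowest of the two numbers known; the only step measured, a number 17 percentage points lower from compound 1 to compound 2 (beyond the scatter), separates it from compound 1 and lies beyond the scatter.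

Compound 3, `CN1CCCN(CCn2ccc3ccc(C(C)(C)O)cc32)CC1`, is not yet measured. It differs from compound 2 by hydroxy in place of hydrogen on a saturated chain carbon bound to an aromatic carbon and two saturated chain carbons. Within the data shown here, no measured step bears on this change: the one known step swaps trifluoromethyl for isopropyl, not hydrogen for hydroxy, so it says nothing about adding a hydroxy group to the chain carbon. With no guide among the measured compounds, the expectation for this assay is a step of about the size of the scatter or smaller, in no particular direction, and a wide range must be allowed.

On that basis compound 3 is estimated at 68%, within 48% to 86%. The step this estimate means is expected to be a number 4 percentage points lower from compound 2 to compound 3 (within the scatter).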

Compound 3, a percentage reported as inhibition, at one concentration (the size of the read-out at that concentration, not a potency): 6%
Beside the measured number, compound 3's estimate is 62 percentage points above it; the measured number lies below the stated range.
By their numbers in this assay, from the lowest: compound 3; then compound 2; then compound 1.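

In this assay, one hydroxy in place of hydrogen, which turns isopropyl into 1-hydroxy-1-methylethyl, gives a number 66 percentage points lower from compound 2 to compound 3 (beyond the scatter) and so accounts for far more than the modest shift seen earlier on replacing trifluoromethyl with isopropyl. This saturated chain carbon bound to an aromatic carbon and two saturated chain carbons is therefore far from indifferent to what it carries, and a change of a single heavy atom there can remove nearly all of the inhibition seen at the concentration tested. Measured against the trifluoromethyl group, 1-hydroxy-1-methylethyl gives a number 83 percentage points lower from compound 1 to compound 3 (beyond the scatter) and stands lowest of the three groups at this place, with both of its steps beyond the scatter. Nothing measured here reveals what lies behind this drop.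

The compounds shown leave open whether the loss is tied to hydroxy alone or would also appear with a methoxy group or an amine on the same carbon. They also leave open whether a hydroxy carried further out, at the end of a longer chain, would give a similarly low number in this assay or would keep the inhibition seen with isopropyl.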